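Alkyl change on the pyridine-type core: isobutyl for isopropyl

The source may report more compounds than this note shows. Statements on the series, on what has been measured and on what is new or still open speak of the compounds shown alone.

Two compounds of the series carry a read-out in a functional assay on the whole organism for inhibition, with Rattus norvegicus as the target, at a dose of 1 mg/kg by the oral route; a higher number here means a stronger effect of the compound at the dose given, a lower number a weaker effect. Compound 1 `Cc1ccc(-c2cc(C(C)C)cc(C(=O)Nc3nn[nH]n3)n2)cc1` gives 20% in this assay, and compound 2 `CC(C)c1cc(C(=O)Nc2nn[nH]n2)nc(-c2ccc(N)cc2)c1` gives 29%. Compound 1 stands lowest of the two numbers, but the nearest point is compound 2, and the one shown step, a number 9 percentage points higher from compound 1 to compound 2 (within the scatter), lies within the scatter, so the two read-outs cannot be ordered.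

Compound 3 `Cc1ccc(-c2cc(CC(C)C)cc(C(=O)Nc3nn[nH]n3)n2)cc1` is not yet measured. It differs from compound 1 in one place: isobutyl in place of isopropyl on an aromatic carbon. The enlargement of the branched chain by one carbon sits on the ring that already carries the (2H-tetrazol-5-yl)carbamoyl group and the 4-methylphenyl group, opposite the ring nitrogen.

Among the measured compounds shown here, no measured step touches this position; the only step known, from compound 1 to compound 2, alters the 4-methylphenyl group and is itself within the scatter. The series therefore gives no ground for a shift beyond the scatter in this assay, and the step from compound 1 to compound 3 is expected at a number 2 percentage points higher from compound 1 to compound 3 (within the scatter). For compound 3 the expected read-out is 22%, with a range from 5% to 40%.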

Compound 3, a percentage reported as inhibition, in the whole organism at one dose (the size of the read-out at that dose, not a potency): 9%
Beside the measured number, compound 3's estimate is 13 percentage points above it, and the stated range covers the measured number.
By their numbers in this assay, from the lowest: compound 3; then compounds 1 and 2 (each within the scatter of the next).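

Among the compounds shown here, the alkyl group opposite the ring nitrogen is the first place where a change in one place moves the read-out beyond the scatter: in this assay the step to isobutyl is a number 11 percentage points lower from compound 1 to compound 3 (beyond the scatter), a modest loss of effect at the dose given. The exchange is small, with isopropyl of 3 heavy atoms giving way to isobutyl of 4 heavy atoms and no ring, hydrogen-bond donor, hydrogen-bond acceptor or net charge entering or leaving, yet this step is read beyond the scatter, whereas a number 9 percentage points higher from compound 1 to compound 2 (within the scatter), on the 4-methylphenyl group, is not. Nothing at hand accounts for the lower read-out with isobutyl.

Open, as far as these compounds go, is whether the read-out at this position keeps falling with a longer chain such as n-pentyl, or holds or rises with a shorter one such as ethyl or a cyclopropyl ring. Also open, from the compounds shown here alone, is whether amino in place of methyl on the aromatic carbon would give a different read-out with isobutyl on the core.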